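A few compounds are considered here, and "the series" means these few. Any claim that something is new, unique, unknown or untested is made for them only; others in the source may bear on it.

Measured compounds:
compound 1 `CC(C)OC(=O)C(O)Cn1cnc2c(N)ncnc21`
compound 2 `COCCOC(=O)C(O)Cn1cnc2c(N)ncnc21`

In a functional assay on PRK cells (Oryctolagus cuniculus) for cytotoxicity (on this read-out lower numbers stand for higher toxicity in this test and higher numbers for lower toxicity in this test), compound 1 gives only a limit, > 400 ug/mL. In this assay compound 2 likewise gives only a limit, > 400 ug/mL. Within the data shown here, compound 2 thus stands at a limit, as does the one other value shown: the limit of > 400 ug/mL in this assay, at which 2 of the 2 values shown sit. The step that the two limits leave unreadable from compound 1 to compound 2 is of unreadable size. Compound 3 `Nc1ncnc2c1ncn2CC(O)C(=O)OC1CCCCC1` differs from compound 2 by cyclohexyl in place of 2-methoxyethyl on an oxygen next to a carbonyl group. Among the measured compounds shown here, the only step bearing on this change, a step that the two limits leave unreadable from compound 1 to compound 2, sits between limits, so no step beyond the scatter is expected in this assay. Compound 3 is therefore expected to give 400 ug/mL, between 150 ug/mL and 800 ug/mL, an expected step of a number no higher from compound 2 to compound 3 (the limit leaves the size open).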

Compound 3, minimum cytotoxic concentration: 100 ug/mL
Beside the measured number, compound 3's estimate is 4.0-fold (0.60 log units) above it; measured number outside the range, below it.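

Cyclohexyl on the oxygen next to a carbonyl group gives the first readable change at this position in this assay with an at least 4.0-fold lower number from compound 2 to compound 3 (0.60 log units; beyond the scatter) and with an at least 4.0-fold lower number from compound 1 to compound 3 (0.60 log units; beyond the scatter) as well. Toxicity in this test therefore responds to the group on this oxygen, with cyclohexyl on the side of higher toxicity. Compound 1 and compound 2 could not show this, as each value is only a limit: the limit of > 400 ug/mL in this assay, at which 2 of the 3 values shown sit.

The step between those two limits cannot be read. On these data alone, whether the ring or the carbon count matters stays open, and a straight hexyl chain or a phenyl on the same oxygen would separate the two.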